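Swapping bromo for methyl in an inactive series

The source may hold more compounds than are shown below. What is called first, only, known or untested is meant among the compounds shown, and "the series" means these compounds.

Compound 1 `CN1C(=O)C(O)(Cc2nnn[nH]2)c2ccccc21`: > 100000 nM (a limit)
Compound 2 `CN1C(=O)C(O)(Cc2nnn[nH]2)c2cc(Cl)ccc21`: > 100000 nM (a limit)
Compound 3 `CN1C(=O)C(O)(Cc2nnn[nH]2)c2cc(Br)ccc21`: > 100000 nM (a limit)

In a functional assay on BT-549 cells (Homo sapiens) for antiproliferative activity, read by MTT assay, with a stated time of 48 h (on this read-out higher numbers stand for weaker inhibition and lower numbers for stronger inhibition), compound 3 gives > 100000 nM, which is a limit and not a number. The other two compounds stand in the same place, and the whole set reads as the limit of > 100000 nM in this assay, at which 3 of the 3 values shown sit. Compound 4 `Cc1ccc2c(c1)C(O)(Cc1nnn[nH]1)C(=O)N2C` carries methyl in place of bromo on an aromatic carbon.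

Going by the values given here, three measured steps bear on this swap: a step that the two limits leave unreadable from compound 1 to compound 2, a step that the two limits leave unreadable from compound 1 to compound 3 and a step that the two limits leave unreadable from compound 2 to compound 3. None of them has a size that can be read, so they point in no direction. Compound 4 is therefore expected to show no change beyond the scatter in this assay, since compound 3 gives only the limit > 100000 nM. The expected step is a step that the limit leaves unreadable from compound 3 to compound 4. For compound 4 the estimate is 120000 nM, with an expected range from 50000 nM to 300000 nM, and a reported limit is the likeliest outcome.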

Compound 4, half-maximal inhibitory concentration: > 100000 nM
Compound 4: a limit, no number; the forecaster's own chance of this, stated with the estimate: 90%; the middle value is on the limit's open side.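

In this assay compound 4 gives > 100000 nM as a limit and not a number, so the steps to compound 4 from compound 1, compound 2 and compound 3 cannot be read. The compounds shown leave open whether any group at this place on the shared core would give a readable value.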